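Replacing the Aryl Group on the Amide Carbonyl

The compounds below may be only part of what the source reports. "The series", "measured", "known", "first", "only" and "open" are said of these compounds alone.

Of the compounds shown here, three built on one shared core have been tested in a functional assay on C8166 cells (Homo sapiens) for cytotoxicity, read by MTT assay; a lower number here means that less compound is tolerated, a higher number that more compound is tolerated. Compound 1 `Cc1cc(S(N)(=O)=O)ccc1NC(=O)COc1ccc(Cl)cc1NC(=O)c1cccc([N+](=O)[O-])c1` gives 58800 nM. Compound 2 `Cc1cc(S(N)(=O)=O)ccc1NC(=O)COc1ccc(Cl)cc1NC(=O)c1cccc(C(F)(F)F)c1` gives 124000 nM, and compound 3 `Cc1cc(S(N)(=O)=O)ccc1NC(=O)COc1ccc(Cl)cc1NC(=O)c1cc(Cl)cc(C#N)c1` gives 131000 nM. Among these three numbers compound 2 holds the second highest; it lies close to compound 3 and further from compound 1. Putting trifluoromethyl in place of nitro on an aromatic carbon gave a 2.1-fold higher number from compound 1 to compound 2 (0.32 log units; beyond the scatter), whereas putting 3-chloro-5-cyanophenyl in place of 3-(trifluoromethyl)phenyl on a carbonyl carbon gave a 1.1-fold higher number from compound 2 to compound 3 (0.02 log units; within the scatter).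

Compound 4 `Cc1cc(S(N)(=O)=O)ccc1NC(=O)COc1ccc(Cl)cc1NC(=O)/C=C/c1ccccc1` differs from compound 2 in one place: 2-phenylethenyl in place of 3-(trifluoromethyl)phenyl on a carbonyl carbon. Going by the values given here, of the measured steps only the one from compound 2 to compound 3 bears on this, since it also exchanged the whole group on the carbonyl carbon, and that step stayed within the scatter; no measured step involves a 2-phenylethenyl group. The expected change is therefore none beyond the scatter, a 1.1-fold lower number from compound 2 to compound 4 (0.05 log units; within the scatter). Compound 4 is estimated to give 110000 nM in this assay, most likely between 45000 nM and 260000 nM.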

Compound 4, half-maximal cytotoxic concentration: 163000 nM
Estimate against measurement, compound 4: 1.5-fold (0.17 log units) below; low and high end bracket the measured number.
By their numbers in this assay, from the lowest: compound 1; then compounds 2, 3 and 4 (each within the scatter of the next).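

In this assay this carbonyl carbon can carry 2-phenylethenyl, a group with a double bond outside the aromatic ring and no fluorine, and the numbers show a 1.3-fold higher number from compound 2 to compound 4 (0.12 log units; within the scatter) and a 1.2-fold higher number from compound 3 to compound 4 (0.09 log units; within the scatter) with no real separation among these three compounds. Going by these compounds alone, the step that does stand out is a 2.8-fold higher number from compound 1 to compound 4 (0.44 log units; beyond the scatter) and it matches what the earlier compounds hinted at, that compound 1 with its 3-nitrophenyl group sits apart from the others. No measurement here explains why these different groups give such similar numbers.

Still open, from the compounds shown here alone, is whether the double bond matters, which the saturated 2-phenylethyl group would test. Also open, going by these compounds, is whether a group with no aromatic ring on this carbonyl carbon, such as a short alkyl chain or an amine, would read like compound 2, compound 3 and compound 4.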